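Propargyl to phenyl on the amine-bound chain carbon

The compounds below may be only part of what the source reports. "The series", "measured", "known", "first", "only" and "open" are said of these compounds alone.

Measured so far in an assay for inhibition of tRNA (cytosine(38)-C(5))-methyltransferase (Homo sapiens), with a stated time of 5 min, tested at 100 uM; on this read-out lower numbers stand for less inhibition and higher numbers for more inhibition at the one concentration tested (going by the name of the read-out):
- compound 1 `C#CCN(CC[C@H](N)C(=O)O)C[C@H]1O[C@@H](n2cnc3c(N)ncnc32)[C@H](O)[C@@H]1O`: 72.2%
- compound 2 `C#CCCN(CC[C@H](N)C(=O)O)C[C@H]1O[C@@H](n2cnc3c(N)ncnc32)[C@H](O)[C@@H]1O`: 30.2%

Compound 2 stands lowest of the two numbers in this assay, the step of a number 42 percentage points lower from compound 1 to compound 2 (beyond the scatter) lying beyond the scatter. Compound 3 `Nc1ncnc2c1ncn2[C@@H]1O[C@H](CN(CC[C@H](N)C(=O)O)Cc2ccccc2)[C@@H](O)[C@H]1O` differs from compound 2 by phenyl in place of propargyl on a saturated chain carbon bound to an amine nitrogen. Within the data shown here, no measured step covers an aromatic group at this position; the only step known, a number 42 percentage points lower from compound 1 to compound 2 (beyond the scatter), shows a large drop on lengthening the chain, so a modest further drop in this assay or no step beyond the scatter is expected. For compound 3 the estimated value is 20%, with a range from 0% to 55%. This expectation corresponds to the step of a number 10.2 percentage points lower from compound 2 to compound 3 (beyond the scatter).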

Compound 3, a percentage reported as inhibition, at one concentration (the size of the read-out at that concentration, not a potency): 56.8%
Beside the measured number, compound 3's estimate is 36.8 percentage points below it; the measured number lies above the stated range.
By their numbers in this assay, from the lowest: compound 2; then compound 3; then compound 1.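

In this assay, a number 26.6 percentage points higher from compound 2 to compound 3 (beyond the scatter) shows that an aromatic ring is accepted at this position, and that the larger group, phenyl, does not give the lower number here. With a number 15.4 percentage points lower from compound 1 to compound 3 (beyond the scatter), ethynyl remains the highest of the three groups, so the order does not follow the heavy-atom count. No measured evidence accounts for this order.

Still open, from the compounds shown here alone, is whether a carboxylic acid or an amine on the phenyl ring changes the number. A longer chain carrying the phenyl is equally unresolved.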